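The source may report more compounds than this note shows. Statements on the series, on what has been measured and on what is new or still open speak of the compounds shown alone.

Compound 1 `Oc1ccc(-c2cc(-c3ccc(Cl)cc3)nc(-c3cccnc3)c2)cc1` is the starting point. In an ADME assay on HEK293 cells (Homo sapiens) for cytotoxicity, read by CCK-8 assay and cell counting, with a stated time of 2 days (on this read-out lower numbers stand for stronger inhibition and higher numbers for weaker inhibition), compound 1 gives 27500 nM, the lowest of the two numbers recorded; its nearest neighbour is compound 2 `Oc1cccc(-c2cc(-c3ccc(Cl)cc3)nc(-c3cccnc3)c2)c1`, which in this assay gives 39500 nM, and the step from compound 1 to compound 2 is a 1.4-fold higher number from compound 1 to compound 2 (0.16 log units; within the scatter). Compound 3 `Oc1ccc(-c2cc(-c3ccc(Cl)cc3)nc(-c3ccsc3)c2)cc1` has not yet been measured in this assay. It differs from compound 1 in one place: thiophen-3-yl in place of pyridin-3-yl on an aromatic carbon. Among the measured compounds shown here, no measured step touches this change, since the single step seen so far alters the hydroxyphenyl group and not the ring that is exchanged here, and that step itself stays within the scatter. For the measured compounds named here, with no step on record for this exchange, no movement beyond the scatter is expected in this assay. Compound 3 is therefore estimated at 30000 nM, within a range of 12000 nM to 75000 nM, which amounts to an expected step of a 1.1-fold higher number from compound 1 to compound 3 (0.04 log units; within the scatter).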

Compound 3, half-maximal inhibitory concentration: 4860 nM
The estimate for compound 3 lay 6.2-fold (0.79 log units) above the measured number; measured number below the stated range.
By their numbers in this assay, from the lowest: compound 3; then compounds 1 and 2 (each within the scatter of the next).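

Among the compounds shown here, exchanging pyridin-3-yl for thiophen-3-yl on the aromatic carbon next to the ring nitrogen gives, in this assay, a 5.7-fold lower number from compound 1 to compound 3 (0.75 log units; beyond the scatter), so this position responds to change, whereas the one earlier step, made on the hydroxyphenyl group, stayed within the scatter. The exchange replaces a six-membered aromatic ring holding a nitrogen with a five-membered one holding a sulfur, so ring size and hetero atom change together, and this single pair cannot tell them apart. Nothing available here accounts for the shift.

The compounds shown leave open whether a phenyl, furan-3-yl or thiophen-2-yl group at this position would give a similar number. They also leave open whether the same exchange would shift the number for compound 2, which carries 3-hydroxyphenyl.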